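A sulfanyl swap on a compound at the limit

The source may report more compounds than this note shows. Statements on the series, on what has been measured and on what is new or still open speak of the compounds shown alone.

In a functional assay, with a stated time of 30 min (a lower number here means a stronger inhibitor, a higher number a weaker inhibitor), compound 1 (`COC(=O)c1c(C(=O)c2c(O)cc(C)cc2OC)c(OC)cc(O)c1[S@@+](C)[O-]`) gives > 100000 nM as a limit of the assay and not a number. Compound 2 (`COC(=O)c1c2c(cc(OC)c1C(=O)c1c(O)cc(C)cc1OC)O[C@@H](OC)CS2`) gives > 100000 nM as a limit too. Compound 3 (`COC(=O)CSc1c(O)cc(OC)c(C(=O)c2c(O)cc(C)cc2OC)c1C(=O)OC`) carries ((methoxycarbonyl)methyl)sulfanyl on an aromatic carbon, para to a methoxy group, in place of the sulfur-bearing group of compound 1 (a group of 6 heavy atoms (3 carbon, 2 oxygen, 1 sulfur; no ring) in place of a group of 3 heavy atoms (1 carbon, 1 oxygen, 1 sulfur; no ring), on an aromatic carbon). Among the measured compounds shown here, no measured step sets a scale, so the expectation rests on the limit of > 100000 nM in this assay, at which 2 of the 2 values shown sit, alone. Only a small gain in inhibition is expected, an estimated a number no higher from compound 1 to compound 3 (the limit leaves the size open) that may not clear the scatter. Compound 3 is estimated at 100000 nM with 30000 nM to 300000 nM as the likely range.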

Compound 3, half-maximal inhibitory concentration: > 100000 nM
Compound 3 was reported as a limit (the forecaster's own chance of this, stated with the estimate: 75%); the middle value lies on the limit itself.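

Compound 1 and compound 3 are both reported as limits of the assay, so the step between them cannot be read. The compounds shown leave open what change to the shared core would give a measurable value in this assay.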